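Cyclobutyl in Place of Thiophene on the Amide

The compounds below may be only part of what the source reports. "The series", "measured", "known", "first", "only" and "open" are said of these compounds alone.

In an assay on isolated protein for inhibition of serine/threonine-protein kinase TBK1 (Homo sapiens) (on this read-out lower numbers stand for stronger inhibition and higher numbers for weaker inhibition), compound 1 `CC(C)n1cc(Nc2ncc(C3CC3)c(NCCCNC(=O)C3CCC3)n2)cn1` gives 4 nM. Compound 2 `O=C(NCCCNc1nc(Nc2cccc(F)c2)ncc1C1CC1)c1cccs1` gives 110 nM in this assay, the higher of the two numbers recorded and therefore the weaker inhibitor, and the gap between compound 1 and compound 2 is beyond the usual scatter of repeated measurements. These two compounds differ from each other in more than one place, so no single change can be read off from that gap. Compound 3 `O=C(NCCCNc1nc(Nc2cccc(F)c2)ncc1C1CC1)C1CCC1` is compound 2 with one change: cyclobutyl in place of thiophen-2-yl on a carbonyl carbon. Compound 1 carries the same cyclobutylcarbonyl group and gives 4 nM, yet it differs from compound 2 elsewhere as well, so that strong value is only a loose guide to what the cyclobutyl group contributes on its own. Among the compounds with values here, with no measured pair isolating this exchange, the expected step of a 1.8-fold lower number from compound 2 to compound 3 (0.26 log units; within the scatter) is modest, toward a lower number, and not certain to clear the scatter. Compound 3 is expected to give about 60 nM in this assay, with a plausible range from 20 nM to 200 nM.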

Compound 3, half-maximal inhibitory concentration: 8 nM
The estimate for compound 3 lay 7.5-fold (0.88 log units) above the measured number, outside the stated range (below it).
By their numbers in this assay, from the lowest: compounds 1 and 3 (each within the scatter of the next); then compound 2.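

In this assay, within the data shown here, cyclobutyl in place of thiophen-2-yl on a carbonyl carbon gives a 14-fold lower number from compound 2 to compound 3 (1.14 log units; beyond the scatter), and this is the first pair to isolate that exchange, showing that this one place on the amide can move the number far more than the scatter alone would. With the cyclobutylcarbonyl group held constant, 3-fluorophenyl in place of 1-isopropyl-1H-pyrazol-4-yl on a nitrogen on an aromatic ring gives a 2.0-fold higher number from compound 1 to compound 3 (0.30 log units; within the scatter), so this pair shows no difference that can be told apart from repeat-to-repeat variation. Nothing given here explains why either exchange has the effect it has.

On these data alone, each exchange rests on a single pair, so it remains open whether the large step belongs to the four-membered ring itself or to the loss of the thiophene, a question that cyclopentyl or phenyl on the same carbonyl carbon could help to settle. As far as these compounds go, it also remains open whether the step would have the same size with 1-isopropyl-1H-pyrazol-4-yl on the nitrogen in place of 3-fluorophenyl.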